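The source may hold more compounds than are shown below. What is called first, only, known or untested is meant among the compounds shown, and "the series" means these compounds.

Measured so far in a functional assay on A549 cells (Homo sapiens) for antiproliferative activity, read by MTT assay, with a stated time of 48 h; on this read-out higher numbers stand for weaker inhibition and lower numbers for stronger inhibition:
- compound 1 `Cc1ccc(-c2nnc(NC(=O)/C=C/c3ccc(C(F)(F)F)cc3)s2)cc1`: 1.61 ug/mL
- compound 2 `O=C(/C=C/c1ccc(C(F)(F)F)cc1)Nc1nnc(-c2ccc(Br)cc2)s1`: 4.68 ug/mL
- compound 3 `Cc1ccc(/C=C/C(=O)Nc2nnc(-c3ccccc3)s2)cc1`: 1.58 ug/mL

Compound 1 sits second highest of the three numbers; compound 3 is within the scatter of it, while the step of a 2.9-fold higher number from compound 1 to compound 2 (0.46 log units; beyond the scatter) is modest but beyond the scatter.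

Compound 4 `Cc1ccc(-c2nnc(NC(=O)/C=C/c3ccccc3)s2)cc1` differs from compound 1 by hydrogen in place of trifluoromethyl on an aromatic carbon. No measured step changes this position: the only step shown alters the other aromatic ring. Compound 3 carries a different group at the corresponding place but also a different far ring, so its value only shows that such changes need not move the number much. Accordingly, a step within the scatter is expected, a 1.2-fold higher number from compound 1 to compound 4 (0.07 log units; within the scatter), and compound 4 is estimated at 1.9 ug/mL (range 0.9 ug/mL to 4 ug/mL).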

Compound 4, half-maximal inhibitory concentration: 1.38 ug/mL
Compound 4: middle estimate off by 1.4-fold (0.14 log units), on the high side, and the stated range covers the measured number.
By their numbers in this assay, from the lowest: compounds 4, 3 and 1 (each within the scatter of the next); then compound 2.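

Hydrogen in place of trifluoromethyl, on the aromatic carbon para to a large group, is the only step read at this position so far. In this assay it gives a 1.2-fold lower number from compound 1 to compound 4 (0.07 log units; within the scatter), so the trifluoromethyl can be lost from compound 1 without a change beyond the scatter. No data shown bear on the reason for this result.

Still open, on these data alone, is whether an amine or a carboxylic acid at this carbon would also stay within the scatter. Also open, as far as these compounds go, is whether the same replacement behaves alike with bromo on the other aromatic ring, as in compound 2.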